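This account rests on a few compounds, and the source may have more. Where it says the series, first, only, none or still open, it means among the compounds named here.

Measured so far, in a functional assay on the whole organism (Tail, strain ICR) with Mus musculus as the target, in the tail flick test, with a stated time of 60 min, at a dose of 25 umol/kg by the oral route; on this read-out higher numbers stand for a stronger effect at the one dose given and lower numbers for a weaker effect:
compound 1 `C[C@H](NC(=O)CN(c1nc(Cl)nc2[nH]cnc12)C1CC1)C(=O)O` gives 44.6%
compound 2 `CC(C)[C@H](NC(=O)CN(c1nc(Cl)nc2[nH]cnc12)C1CC1)C(=O)OCc1ccccc1` gives 55.5%
compound 3 `NC(=O)CC[C@H](NC(=O)CN(c1nc(Cl)nc2[nH]cnc12)C1CC1)C(=O)O` gives 38.4%

Compound 3 holds the lowest of the three numbers; its gap to compound 1 lies within the scatter, its gap to compound 2 beyond it. Compound 4 `CC(C)[C@H](NC(=O)CN(c1nc(Cl)nc2[nH]cnc12)C1CC1)C(=O)O` differs from compound 3 by isopropyl in place of 2-carbamoylethyl on a saturated chain carbon bound to an amide-type nitrogen and a carbonyl carbon. Among the measured compounds shown here, the one measured step that bears on this place is a number 6.2 percentage points lower from compound 1 to compound 3 (within the scatter), a swap of the side chain at the same saturated chain carbon, within the scatter. Compound 2 shares the isopropyl group with compound 4 but carries a benzyl ester, so its value shows only that this side chain is compatible with a number in the upper part of the range. The step is therefore expected to be small, probably a modest rise, as a number 6.6 percentage points higher from compound 3 to compound 4 (within the scatter). Compound 4 is estimated at 45%, between 32% and 58%.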

Compound 4, a percentage reported as activity, at one dose (the size of the read-out at that dose, not a potency): 38.8%
Compound 4: middle estimate off by 6.2 percentage points, on the high side, within the range that was stated.
By their numbers in this assay, from the lowest: compounds 3, 4 and 1 (each within the scatter of the next); then compound 2.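

In this assay the side chain on this saturated chain carbon makes no readable difference among the free acids: a number 0.4 percentage points higher from compound 3 to compound 4 (within the scatter) and a number 5.8 percentage points lower from compound 1 to compound 4 (within the scatter), so isopropyl, methyl and 2-carbamoylethyl cannot be told apart. The isopropyl pair adds a step beyond the scatter at the ester instead, with hydrogen in place of benzyl on the oxygen: a number 16.7 percentage points lower from compound 2 to compound 4 (beyond the scatter). Nothing available accounts for these numbers.

As far as these compounds go, whether a benzyl ester would give a similar step with methyl or 2-carbamoylethyl on this carbon remains open. So does the effect of an amine or a longer chain there.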